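Adding a Methyl to the Amide Chain of Compound 1

The compounds below may be only part of what the source reports. "The series", "measured", "known", "first", "only" and "open" are said of these compounds alone.

Among the compounds with values here, compound 1 `CCC(=O)N(Cc1ccc(OC)c(O)c1)c1cc(OC)c(OC)c(OC)c1` has the lower of the two numbers measured so far: in a functional assay on KYSE-450 cells (Homo sapiens) for inhibition, read by MTT assay, with a stated time of 48 h (a higher number here means a weaker inhibitor, a lower number a stronger inhibitor), compound 1 gives 98 nM, while compound 2 `COc1ccc(CNc2cc(OC)c(OC)c(OC)c2)cc1F` gives 46200 nM, a far weaker result. Compound 3 `COc1ccc(CN(C(=O)C(C)C)c2cc(OC)c(OC)c(OC)c2)cc1O` differs from compound 1 in a single place: methyl in place of hydrogen on a saturated chain carbon bound to a carbonyl carbon and a saturated chain carbon. The new carbon sits on a saturated chain carbon bound to a carbonyl carbon, so the propanoyl becomes isopropylcarbonyl. Within the data shown here, no measured pair shows what such a change does here, so for compound 3 a step within the usual scatter is expected, in either direction, meaning a 1.2-fold higher number from compound 1 to compound 3 (0.09 log units; within the scatter). Compound 3 is estimated at 120 nM, with a range from 40 nM to 400 nM.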

Compound 3, half-maximal inhibitory concentration: 390 nM
Beside the measured number, compound 3's estimate is 3.3-fold (0.51 log units) below it; the range from low to high includes it.
By their numbers in this assay, from the lowest: compound 1; then compound 3; then compound 2.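

With methyl in place of hydrogen on this saturated chain carbon, the result is a 4.0-fold higher number from compound 1 to compound 3 (0.60 log units; beyond the scatter), a modest loss of strength from a single added carbon. Within the data shown here, this is the first measured step at this place, and it shows that the change from propanoyl to isopropylcarbonyl does alter the result, beyond the usual scatter. No measured evidence here explains the loss. Still open, from the compounds shown here alone, is whether a smaller acetyl group, a longer butanoyl chain or a cyclopropylcarbonyl group would go the same way. An amine on this chain also remains untested among the compounds shown.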